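Ethyl in Place of Pyrazin-2-yl on the Amide Nitrogen

The source may hold more compounds than are shown below. What is called first, only, known or untested is meant among the compounds shown, and "the series" means these compounds.

Compound 3 `Cc1ccc(OCC(=O)N(Cc2cccs2)c2cnccn2)cc1` gives 1240 nM in an assay on HEK293 cells for agonist activity at transient receptor potential cation channel subfamily M member 8 (Homo sapiens), read by fluorescence and calcium flux, with a stated time of 15 min (on this read-out higher numbers stand for an effect only at larger amounts of compound and lower numbers for an effect already at smaller amounts), the lowest of the three numbers shown, though its gap to compound 1 is within the scatter. Compound 1 `CCN(Cc1ccccc1)C(=O)COc1ccc(C)cc1` gives 1880 nM, while compound 2 `CCN(Cc1ccccn1)C(=O)COc1ccc(C)cc1` gives 16000 nM, clearly beyond the scatter from compound 3. Among the compounds with values here, the single step measured so far, an 8.5-fold higher number from compound 1 to compound 2 (0.93 log units; beyond the scatter), concerns the ring on the chain carbon, not the amide nitrogen. Compound 4 `CCN(Cc1cccs1)C(=O)COc1ccc(C)cc1` differs from compound 3 by ethyl in place of pyrazin-2-yl on an amide-type nitrogen. Within the data shown here, no measured step covers this exchange, so the expectation leans on compound 1 and compound 3, which carry ethyl or pyrazin-2-yl there and give similar values. Compound 4 is therefore expected to give about 1500 nM, between 500 nM and 5000 nM. This amounts to an expected 1.2-fold higher number from compound 3 to compound 4 (0.08 log units; within the scatter).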

Compound 4, half-maximal effective concentration: 8 nM
For compound 4 the middle estimate is 190-fold (2.27 log units) above the measured one, outside the stated range (below it).
By their numbers in this assay, from the lowest: compound 4; then compounds 3 and 1 (each within the scatter of the next); then compound 2.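

Ethyl in place of pyrazin-2-yl on an amide-type nitrogen gives a 160-fold lower number from compound 3 to compound 4 (2.19 log units; beyond the scatter) in this assay, so this position matters greatly when thiophen-2-yl sits on the saturated chain carbon. With ethyl kept on that nitrogen, the ring on the chain carbon also matters: thiophen-2-yl in place of phenyl gives a 240-fold lower number from compound 1 to compound 4 (2.37 log units; beyond the scatter), and thiophen-2-yl in place of pyridin-2-yl gives a 2000-fold lower number from compound 2 to compound 4 (3.30 log units; beyond the scatter).

Nothing shown here explains why these steps are so large. As far as these compounds go, whether a propyl chain or a cyclopropyl group on that nitrogen would keep such a low number remains open.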